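A few compounds are considered here, and "the series" means these few. Any claim that something is new, unique, unknown or untested is made for them only; others in the source may bear on it.

Working notes on the series in a functional assay on HL-60 cells (Homo sapiens) for inhibition; a higher number here means a weaker inhibitor of growth, a lower number a stronger inhibitor of growth. Of the compounds shown here, three have numbers so far. Compound 1 `C=C(C)C(=O)c1ccc(OCc2nc(-c3ccccc3)no2)cc1C` gives 6700 nM. Compound 2 `C=C(C)C(=O)c1ccc(OCc2nc(-c3ccccc3)no2)cc1Cl` gives 5400 nM. Compound 3 `C=C(C)C(=O)c1ccc(OCc2nc(-c3ccc(C(F)(F)F)cc3)no2)cc1Cl` gives 1900 nM.

Compound 2 sits at the high end of these three numbers, level with its nearest neighbour, the step being a 1.2-fold lower number from compound 1 to compound 2 (0.09 log units; within the scatter). The clearly lower number belongs to compound 3, reached by a 2.8-fold lower number from compound 2 to compound 3 (0.45 log units; beyond the scatter).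

Compound 4 `C=C(C)C(=O)c1ccc(OCc2nc(-c3ccccc3)no2)cc1Br` has not yet been measured. Its change is bromo in place of chloro on an aromatic carbon, ortho to a (1-methylethenyl)carbonyl group.

The measured step at this same place, chloro in place of methyl, is a 1.2-fold lower number from compound 1 to compound 2 (0.09 log units; within the scatter), so that exchange left the number within the scatter. The trifluoromethyl step, a 2.8-fold lower number from compound 2 to compound 3 (0.45 log units; beyond the scatter), was made elsewhere in the molecule and bears only weakly on this change. Among the compounds with values here, no bromo compound has been measured, so the expectation rests on that single exchange at this place.

No shift beyond the scatter is expected in this assay. The expected step is a 1.1-fold lower number from compound 2 to compound 4 (0.03 log units; within the scatter). Compound 4 is estimated at 5000 nM. The expected range for that estimate runs from 2800 nM to 9000 nM.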

Compound 4, concentration for 50% growth inhibition: 7900 nM
Compound 4: the middle estimate sits 1.6-fold (0.20 log units) below what was measured, within the range that was stated.
By their numbers in this assay, from the lowest: compound 3; then compounds 2, 1 and 4 (each within the scatter of the next).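

In this assay, the aromatic carbon ortho to a (1-methylethenyl)carbonyl group now has three substituents to compare, and the halogen exchange gives a 1.5-fold higher number from compound 2 to compound 4 (0.17 log units; within the scatter) while the direct exchange of methyl for bromo gives a 1.2-fold higher number from compound 1 to compound 4 (0.07 log units; within the scatter) with the rest of the molecule unchanged. With methyl, chloro and bromo all tested here, every exchange at this place stays within the scatter, so compounds 1, 2 and 4 cannot be told apart, and a second halogen adds no separation that the earlier chloro and methyl pair had failed to show. Within these compounds, the only step beyond the scatter remains the trifluoromethyl change made elsewhere in the molecule, and nothing available gives a reason for the flat picture at this place.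

From the compounds shown here alone, it remains open whether a group of a different kind at this carbon, such as a methoxy group, an amine or a carboxylic acid, would move the number beyond the scatter. Going by these compounds, it is also open whether the trifluoromethyl gain seen with chloro at this place would carry over with bromo or methyl there.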